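Replacing trifluoromethyl with methoxy in compound 2

The source may report more compounds than this note shows. Statements on the series, on what has been measured and on what is new or still open speak of the compounds shown alone.

In a functional assay on MCF7 cells (Homo sapiens) for inhibition, read by CCK-8 assay, with a stated time of 48 h (a higher number here means a weaker inhibitor, a lower number a stronger inhibitor), compound 1 (`COc1cc(-c2ccnc3cc(-c4cn(CO)c5ccccc45)nn23)cc(OC)c1OC`) gives 19 nM while compound 2 (`COc1cc(-c2ccnc3cc(-c4ccc(C(F)(F)F)cc4)nn23)cc(OC)c1OC`) gives 2440 nM as the higher of the two numbers, a gap beyond the scatter. Compound 3 (`COc1ccc(-c2cc3nccc(-c4cc(OC)c(OC)c(OC)c4)n3n2)cc1`) carries methoxy in place of trifluoromethyl on an aromatic carbon, para to a large group (methoxy in place of trifluoromethyl on an aromatic carbon). Within the data shown here, no measured pair shows this change, so the expectation is loose. In this assay a fall in the number beyond the scatter is expected, with an estimated step of a 6.1-fold lower number from compound 2 to compound 3 (0.79 log units; beyond the scatter) that remains uncertain. Compound 3 is expected at 400 nM with an estimated range of 60 nM to 2500 nM in this measurement.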

Compound 3, half-maximal inhibitory concentration: 125 nM
The estimate for compound 3 lay 3.2-fold (0.51 log units) above the measured number, and the stated range covers the measured number.
By their numbers in this assay, from the lowest: compound 1; then compound 3; then compound 2.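

In this assay there is a 20-fold lower number from compound 2 to compound 3 (1.29 log units; beyond the scatter) when methoxy replaces trifluoromethyl on this aromatic carbon, para to a large group. This is the first pair shown that differs in one place only, and it shows that the group at this place alone can move the number well beyond the scatter. From the compounds shown here alone, whether an amine, a hydroxyl or a longer chain such as ethoxy at the same place would lower the number further remains open. Nothing shown gives a reason for the size of this step.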